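Nitro to Chloro: An Untested Change

A few compounds are considered here, and "the series" means these few. Any claim that something is new, unique, unknown or untested is made for them only; others in the source may bear on it.

In a functional assay on A549 cells (Homo sapiens) for antiproliferative activity, read by MTT assay (a higher number here means a weaker inhibitor, a lower number a stronger inhibitor), compound 1 `COc1ccc(-c2ccnc(Nc3ccc([N+](=O)[O-])cc3)n2)cc1` gives 2730 nM, the second highest of three numbers. Compound 3 `O=[N+]([O-])c1ccc(Nc2nccc(-c3ccc(Cl)c(Cl)c3)n2)cc1` stands lower at 720 nM, and compound 2 `O=[N+]([O-])c1ccc(Nc2nccc(-c3ccc(F)cc3)n2)cc1` stands higher at 84000 nM. Compound 4 `COc1ccc(-c2ccnc(Nc3ccc(Cl)cc3)n2)cc1` has not been measured. It carries chloro in place of nitro on an aromatic carbon, para to a large group: chloro in place of nitro on an aromatic carbon. Among the compounds with values here, no measured step tests this change. The available steps alter another part of the molecule: a 31-fold higher number from compound 1 to compound 2 (1.49 log units; beyond the scatter) is large, a 3.8-fold lower number from compound 1 to compound 3 (0.58 log units; beyond the scatter) is modest and a 120-fold lower number from compound 2 to compound 3 (2.07 log units; beyond the scatter) is large. They show that single changes can move this assay widely, so the range stays broad, but they give no direction here. The estimated step is a 1.1-fold higher number from compound 1 to compound 4 (0.04 log units; within the scatter), so no change beyond the scatter is expected. For compound 4 the estimate is 3000 nM, with an expected range of 600 nM to 15000 nM.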

Compound 4, half-maximal inhibitory concentration: 20900 nM
Compound 4: the middle estimate sits 7.0-fold (0.84 log units) below what was measured, and the stated range ends below it.
By their numbers in this assay, from the lowest: compound 3; then compound 1; then compound 4; then compound 2.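

In this assay, within the data shown here, the place para to a large group, untouched by the earlier steps, proves able to move the number: chloro in place of nitro gives a 7.7-fold higher number from compound 1 to compound 4 (0.88 log units; beyond the scatter), a modest loss. The earlier steps shown here showed change only elsewhere in the molecule, whereas this one shows that, with the 4-methoxyphenyl group present, nitro gives the lower number of these two groups. Nothing measured here bears on the reason for this difference.

On these data alone, whether an amine or a carboxylic acid at this place would give a lower number than nitro remains open. So does whether the same step would hold with 3,4-dichlorophenyl in place of 4-methoxyphenyl.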